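Swapping chloro for fluoro on a benzyl-triazole chromone

The source may hold more compounds than are shown below. What is called first, only, known or untested is meant among the compounds shown, and "the series" means these compounds.

Three compounds share one core and differ only in the halogen and its place on the benzyl ring. Compound 1 is `O=c1ccoc2cc(OCc3cn(Cc4ccccc4Br)nn3)ccc12`, compound 2 is `O=c1ccoc2cc(OCc3cn(Cc4cccc(Br)c4)nn3)ccc12` and compound 3 is `O=c1ccoc2cc(OCc3cn(Cc4ccccc4Cl)nn3)ccc12`. In an ADME assay on L02 cells (Homo sapiens) for cytotoxicity, read by MTT assay, with a stated time of 48 h (on this read-out lower numbers stand for stronger inhibition and higher numbers for weaker inhibition), compound 1 reaches only the limit of the assay, > 300000 nM. In this assay compound 2 likewise reaches only the limit, > 300000 nM. Compound 3 stands at the same limit in this assay, > 300000 nM, so no number is known for it, only that it lies beyond the range measured. The steps between these three, a step that the two limits leave unreadable from compound 1 to compound 2, a step that the two limits leave unreadable from compound 1 to compound 3 and a step that the two limits leave unreadable from compound 2 to compound 3, cannot be sized for that reason, as the limit of > 300000 nM in this assay, at which 3 of the 3 values shown sit, shows.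

Compound 4 is `O=c1ccoc2cc(OCc3cn(Cc4ccccc4F)nn3)ccc12`. It differs from compound 3 by fluoro in place of chloro on an aromatic carbon. Within the data shown here, none of the measured steps can be read, so no direction or size is known for the change from chloro to fluoro here; the only guide is that every measured compound sits at the limit. The expected step from compound 3 to compound 4 in this assay is therefore a step that the limit leaves unreadable from compound 3 to compound 4, meaning none beyond the scatter. Compound 4 is expected to give about 400000 nM in this assay, within a range of 150000 nM to 1200000 nM, and most likely to be reported as a limit again.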

Compound 4, half-maximal inhibitory concentration: > 300000 nM
Compound 4 was reported as a limit (the forecaster's own chance of this, stated with the estimate: 85%); the middle value lies beyond the limit too.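

No step from compound 1, compound 2 or compound 3 to compound 4 can be read in this assay, because all four compounds stand at the same point: the limit of > 300000 nM in this assay, at which 4 of the 4 values shown sit.

These compounds leave open whether the choice of halogen, or its place on the benzyl ring, makes any difference in this assay, since none of them has a measured number.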